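The source may report more compounds than this note shows. Statements on the series, on what has been measured and on what is new or still open speak of the compounds shown alone.

Working notes on the series.

Compound 1, `COc1ccc(-c2cc(-c3cc(C(C)C)c(O)cc3C)[nH]c(=O)c2C#N)c(OC)c1`, is the reference point for this step. In a functional assay for inhibition, tested at 80 ug/mL (a higher number here means a stronger effect of the compound at the concentration tested, a lower number a weaker effect), compound 1 gives 55%. Among the three compounds measured it stands lowest, though its nearest neighbour is close: compound 3, `COc1ccc(-c2cc(-c3cc(C(C)C)c(O)cc3C)[nH]c(=O)c2C#N)cc1OC`, gives 58%, and compound 2, `COc1cc(OC)c(-c2cc(-c3cc(C(C)C)c(O)cc3C)[nH]c(=O)c2C#N)c(OC)c1`, gives 79%. The two single-point steps from compound 1 are a number 24 percentage points higher from compound 1 to compound 2 (beyond the scatter) and a number 3 percentage points higher from compound 1 to compound 3 (within the scatter).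

The new compound is compound 4, `Cc1cc(O)c(C(C)C)cc1-c1cc(-c2ccc(N(C)C)cc2)c(C#N)c(=O)[nH]1`. Its difference from compound 1 is 4-(dimethylamino)phenyl in place of 2,4-dimethoxyphenyl on an aromatic carbon.

Neither measured step is a direct model. Both keep the methoxy-bearing phenyl and only add a methoxy or move one; neither replaces the whole aryl by a different substituent type. The step from compound 1 to compound 3, within the scatter, shows that rearranging the two methoxy groups changes little, while the step from compound 1 to compound 2 shows that a third methoxy is worth a modest gain. Among the measured compounds shown here, removing both methoxy groups in favour of a dimethylamino has no precedent here, so no step beyond the scatter is expected in either direction, and the expected step is no change at the digits printed from compound 1 to compound 4 (within the scatter). The estimate for compound 4 is therefore 55%, expected to lie between 35% and 75%.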

Compound 4, a percentage reported as inhibition, at one concentration (the size of the read-out at that concentration, not a potency): 66.5%
Compound 4: the middle estimate sits 11.5 percentage points below what was measured; the range from low to high includes it.
By their numbers in this assay, from the lowest: compounds 1, 3 and 4 (each within the scatter of the next, the first and the last beyond it); then compound 2.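

At this place, on the aromatic carbon opposite the ring nitrogen, the methoxy groups of compounds 1 to 3 prove not to be required: in this assay, 4-(dimethylamino)phenyl in place of 2,4-dimethoxyphenyl gives a number 11.5 percentage points higher from compound 1 to compound 4 (beyond the scatter). The picture depends on the reference, since 4-(dimethylamino)phenyl in place of 3,4-dimethoxyphenyl gives a number 8.5 percentage points higher from compound 3 to compound 4 (within the scatter), so the change counts as a gain only against compound 1 and cannot be separated from compound 3. No measurement is at hand that accounts for either step.

The compounds shown leave open whether the dimethylamino group itself contributes to these numbers, which an unsubstituted phenyl, or a phenyl carrying a primary amine or a carboxylic acid in the same place, would help to settle. Among the compounds shown here, also open is whether adding a methoxy to the 4-(dimethylamino)phenyl would bring a gain like the one seen with the third methoxy, a number 24 percentage points higher from compound 1 to compound 2 (beyond the scatter), since that addition has so far been seen only on the dimethoxyphenyl of compound 1.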